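Sulfur-linked heteroaryl variants on the shared core

The source may hold more compounds than are shown below. What is called first, only, known or untested is meant among the compounds shown, and "the series" means these compounds.

Measured compounds:
compound 1 `COC(=O)c1cc(OCC(=O)[C@H](CC(=O)O)NC(=O)[C@@H](NC(=O)COc2cccc3ccccc23)C(C)C)no1` gives 71000 nM
compound 2 `CC(C)[C@H](NC(=O)COc1cccc2ccccc12)C(=O)N[C@@H](CC(=O)O)C(=O)CSc1ncc[nH]1` gives > 200000 nM, a limit of the assay
compound 3 `CC(C)[C@H](NC(=O)COc1cccc2ccccc12)C(=O)N[C@@H](CC(=O)O)C(=O)CSc1nnnn1-c1ccccc1` gives 153000 nM

In a functional assay on Jurkat cells (Homo sapiens) for inhibition (a higher number here means a weaker inhibitor, a lower number a stronger inhibitor), compound 1 gives 71000 nM. For compound 2 the this assay value is a limit of the assay, > 200000 nM. Compound 3 gives 153000 nM in this assay and stands highest of the two numbers, its nearest neighbour being compound 1, through a 2.2-fold higher number from compound 1 to compound 3 (0.33 log units; beyond the scatter). The other exchange on the saturated chain carbon bound to the carbonyl carbon, an at least 2.8-fold higher number from compound 1 to compound 2 (0.44 log units; beyond the scatter), runs into the limit (the limit of > 200000 nM in this assay, at which 1 of the 3 values shown sits). Going by the values given here, the only step that alters just the group on the sulfur is an at least 1.3-fold lower number from compound 2 to compound 3 (0.11 log units; that floor lies within the scatter), whose floor lies within the scatter.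

Compound 4 `CC(C)[C@H](NC(=O)COc1cccc2ccccc12)C(=O)N[C@@H](CC(=O)O)C(=O)CSc1nc2ccccc2s1` differs from compound 3 by 1,3-benzothiazol-2-yl in place of 1-phenyl-1H-tetrazol-5-yl on a sulfur. Among the compounds with values here, the one step that bears on it, an at least 1.3-fold lower number from compound 2 to compound 3 (0.11 log units; that floor lies within the scatter), is the sulfur-bound swap, and it was small, so no step beyond the scatter in this assay is expected in either direction. For compound 4 the estimated step is a 1.1-fold lower number from compound 3 to compound 4 (0.04 log units; within the scatter). Compound 4 is expected to give about 140000 nM in this assay, with a range from 55000 nM to 300000 nM.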

Compound 4, half-maximal inhibitory concentration: > 200000 nM
Compound 4 gave a limit, no number; the forecaster's own chance of this, stated with the estimate: 35%; at least 1.4-fold (0.15 log units) between middle value and limit.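

In this assay compound 4 gives > 200000 nM, a limit of the assay and not a number. Replacing 1-phenyl-1H-tetrazol-5-yl with 1,3-benzothiazol-2-yl on the sulfur gives an at least 1.3-fold higher number from compound 3 to compound 4 (0.11 log units; that floor lies within the scatter), so this exchange does not establish a real separation between the two groups, whereas the exchange on the saturated chain carbon gives an at least 2.8-fold higher number from compound 1 to compound 4 (0.44 log units; beyond the scatter), which makes (1,3-benzothiazol-2-yl)sulfanyl the third sulfur-linked group shown to sit on the weaker side of compound 1, with no exception among the compounds shown. Compound 2 and compound 4 stop at the same limit, so the step between them cannot be read: the limit of > 200000 nM in this assay, at which 2 of the 4 values shown sit.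

The compounds shown do not separate the effect of the linking oxygen in compound 1 from that of the group it carries, and the true standing of compound 2 and compound 4 remains hidden behind the limit. From the compounds shown here alone, what a carboxylic acid or an amine on the group attached to the sulfur would do to the number also remains open.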